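Methoxy to Hydroxy: An Expected Step in Growth Inhibition

The compounds below may be only part of what the source reports. "The series", "measured", "known", "first", "only" and "open" are said of these compounds alone.

Measured so far:
compound 1, `O=C(Nc1cccc(-n2cc(-c3ccncc3)c(-c3ccc(Cl)c(O)c3)n2)c1)Nc1cccc(C(F)(F)F)c1`, 1950 nM
compound 2, `COc1cc(-c2nn(-c3cccc(NC(=O)Nc4cc(C(F)(F)F)cc(C(F)(F)F)c4)c3)cc2-c2ccncc2)ccc1Cl`, 978 nM

Of the compounds shown here, two have been measured in a functional assay on SF-268 cells (Homo sapiens) for inhibition, read by sulforhodamine B assay, with a stated time of 48 h; on this read-out higher numbers stand for weaker inhibition of growth and lower numbers for stronger inhibition of growth. Compound 1 gives 1950 nM, and compound 2 gives 978 nM. Compound 2 holds the lower of the two numbers, but its gap to compound 1 lies within the scatter, so the two values show no real difference. Going by the values given here, compound 1 and compound 2 differ in more than one place, so no single step between them can be read.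

The next compound, compound 3, `O=C(Nc1cccc(-n2cc(-c3ccncc3)c(-c3ccc(Cl)c(O)c3)n2)c1)Nc1cc(C(F)(F)F)cc(C(F)(F)F)c1`, has not been measured. It differs from compound 2 in one place: hydrogen in place of methyl on an oxygen on an aromatic ring, that is, methoxy becomes hydroxy on the 4-chloro-3-methoxyphenyl group, giving 4-chloro-3-hydroxyphenyl.

Among the compounds with values here, no step of this kind between measured compounds is available, so the expectation rests on the values shown. Compound 1 also carries the hydroxy group and gives 1950 nM, which stays within the scatter of compound 2. The step of a 1.3-fold higher number from compound 2 to compound 3 (0.12 log units; within the scatter) is therefore expected to be small, in the direction of a slightly higher number, and not clearly beyond the scatter.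

Compound 3 is thus estimated to give 1300 nM, with a likely range from 500 nM to 3500 nM.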

Compound 3, concentration for 50% growth inhibition: 846 nM
Estimate against measurement, compound 3: 1.5-fold (0.19 log units) above, and the stated range covers the measured number.
By their numbers in this assay, from the lowest: compounds 3, 2 and 1 (each within the scatter of the next, the first and the last beyond it).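

In this assay, the step from methoxy to hydroxy on the 4-chloro-3-methoxyphenyl group gives a 1.2-fold lower number from compound 2 to compound 3 (0.06 log units; within the scatter), so among these compounds, replacing methyl with hydrogen on this oxygen leaves growth inhibition without a real difference. With the hydroxy group held constant, trifluoromethyl in place of hydrogen on an aromatic carbon gives a 2.3-fold lower number from compound 1 to compound 3 (0.36 log units; beyond the scatter), a modest step and the only single change shown here that goes beyond the scatter. The compounds thus show that, in this small set, the number responds to the added trifluoromethyl group and not to the methyl on the oxygen, although nothing available explains either step.

The compounds shown leave open whether an ethoxy group or a longer chain on that oxygen, or an amine in place of the hydroxy group, would also leave the number unchanged. Going by these compounds alone, they also leave open whether the trifluoromethyl step would be the same with methoxy in place of hydroxy, since compound 1 and compound 2 differ in more than one place and no single step between them can be read.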